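From fluoromethyl to trifluoromethyl in compound 4

The source may report more compounds than this note shows. Statements on the series, on what has been measured and on what is new or still open speak of the compounds shown alone.

- compound 1 `CCNC(=O)Nc1sc2ccccc2c1C(=O)N1CCN(C2CCN(C(=O)C(C)(C)C)CC2)CC1` gives 450 nM
- compound 2 `CCNC(=O)Nc1sc2ccccc2c1C(=O)N1CCN(C2CCN(C(=O)OCC)CC2)CC1` gives 228 nM
- compound 3 `CCNC(=O)Nc1sc2ccccc2c1C(=O)N1CCN(C2CCN(C(=O)OC(C)(C)CF)CC2)CC1` gives 61 nM

In a functional assay on HepG2 cells (Homo sapiens) for inhibition, read by scintillation counting, with a stated time of 2 h (a higher number here means a weaker inhibitor, a lower number a stronger inhibitor), compound 3 gives 61 nM and holds the lowest of the three numbers, beyond the scatter from both others. Compound 4 `CCNC(=O)Nc1sc2ccccc2c1C(=O)N1CCN(C2CCN(C(=O)OC(C)(C)C(F)(F)F)CC2)CC1` has trifluoromethyl in place of fluoromethyl on a saturated chain carbon bound to an oxygen next to a carbonyl group and two saturated chain carbons and awaits measurement. Within the data shown here, no measured step changes this group alone. Only indirectly do a 3.7-fold lower number from compound 2 to compound 3 (0.57 log units; beyond the scatter) and a 7.4-fold lower number from compound 1 to compound 3 (0.87 log units; beyond the scatter) bear on it, as two modest steps that end on the fluoromethyl group. Among the measured compounds shown here, a small further move toward a lower number is therefore expected in this assay with the estimated change being a 1.4-fold lower number from compound 3 to compound 4 (0.13 log units; within the scatter) and no larger than those steps. Expected for compound 4 is 45 nM within a range of 17 nM to 120 nM as estimated.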

Compound 4, half-maximal inhibitory concentration in the HepG2 assay: 81 nM
Beside the measured number, compound 4's estimate is 1.8-fold (0.26 log units) below it; measured number inside the range.
By their numbers in the HepG2 assay, from the lowest: compounds 3 and 4 (each within the scatter of the next); then compounds 2 and 1 (each within the scatter of the next).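

In the HepG2 assay, compound 4 gives 81 nM, and trifluoromethyl in place of fluoromethyl gives a 1.3-fold higher number from compound 3 to compound 4 (0.12 log units; within the scatter), so this change alone stays within the scatter, while the lower numbers relative to the other compounds persist at a 2.8-fold lower number from compound 2 to compound 4 (0.45 log units; beyond the scatter) and a 5.6-fold lower number from compound 1 to compound 4 (0.74 log units; beyond the scatter). In a physicochemical assay, read by HPLC, with a stated time of 3 h, at pH 1.2 (on this read-out higher numbers stand for a more stable compound and lower numbers for a less stable compound), compound 3 gives 98% and compound 4 gives 100%, and the same change gives a number 2 percentage points higher from compound 3 to compound 4 (within the scatter), again within the scatter. No supporting evidence is available to explain either result. The compounds shown leave open whether difluoromethyl or a longer chain such as pentafluoroethyl at this position would keep the number in the HepG2 assay within the scatter.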